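The source may report more compounds than this note shows. Statements on the series, on what has been measured and on what is new or still open speak of the compounds shown alone.

The measured compounds in a functional assay on MCF7 cells (Homo sapiens) for antiproliferative activity, read by MTT assay; a higher number here means a weaker inhibitor, a lower number a stronger inhibitor:

Compound 1 `CC(C)Nc1nc(Nc2ccc(N3CCN(C)CC3)cc2)ncc1/N=C/c1ccccc1` gives > 100000 nM, which is a limit of the assay and not a number.
Compound 2 `CC(C)Nc1nc(Nc2ccc(N3CCN(C)CC3)cc2)ncc1/N=C/c1cccs1` gives 91100 nM.
Compound 3 `CC(C)Nc1nc(Nc2ccc(S(N)(=O)=O)cc2)ncc1/N=C/c1ccccc1` gives > 100000 nM, again a limit of the assay.

Compound 4 `CC(C)Nc1nc(Nc2ccc(S(N)(=O)=O)cc2)ncc1/N=C/c1cccs1` has not been measured. Compound 2 differs from compound 1 in one place, (thiophen-2-yl in place of phenyl on a carbon with a double bond to nitrogen). That change made an at least 1.0-fold lower number from compound 1 to compound 2 (0.04 log units; that floor lies within the scatter). Compound 3 differs from compound 1 in its core, (sulfamoyl in place of 4-methylpiperazin-1-yl on an aromatic carbon). Between them the step is a step that the two limits leave unreadable from compound 1 to compound 3. Compound 3 sits at the limit of > 100000 nM in this assay, at which 2 of the 3 values shown sit.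

Compound 4 differs from compound 3 in the same way as compound 2 from compound 1, namely (thiophen-2-yl in place of phenyl on a carbon with a double bond to nitrogen), and the place is the same word for word, so this is the same change. Since the earlier step from compound 1 to compound 2 was within scatter, and compound 3 is only known as a limit, compound 4 is expected to stay in the same region. The expected step is a number no higher from compound 3 to compound 4 (the limit leaves the size open). The estimate for compound 4 is 100000 nM, with a range from 50000 nM to 200000 nM.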

Compound 4, half-maximal inhibitory concentration: 50200 nM
The estimate for compound 4 lay 2.0-fold (0.30 log units) above the measured number; low and high end bracket the measured number.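

In this assay, thiophen-2-yl in place of phenyl gives an at least 1.9-fold lower number from compound 3 to compound 4 (0.29 log units; that floor lies within the scatter), which points the same way as on the core of compound 1, though this is a floor inside the usual noise and shows no clear gain. On these data alone, compound 3 gives > 100000 nM, which is a limit of the assay and not a number, so the true size of this step stays unknown. The change can therefore be said to carry over to the second core without any conflict, but it cannot be said to have the same size on both: the same change on two cores in this assay, an at least 1.0-fold lower number (0.04 log units; that floor lies within the scatter) from compound 1 to compound 2 and an at least 1.9-fold lower number (0.29 log units; that floor lies within the scatter) from compound 3 to compound 4; the limit leaves it open whether they differ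

With thiophen-2-yl in place, sulfamoyl instead of 4-methylpiperazin-1-yl gives a 1.8-fold lower number from compound 2 to compound 4 (0.26 log units; within the scatter), so these compounds do not separate the two groups, and the steps that have a limit at both ends cannot be read. Still open, as far as these compounds go, is whether a different group in that position, such as an amine or a carboxylic acid, would move the number clearly beyond the noise.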